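Swapping Furan for Pyrrole: Expected Growth Inhibition of Compound 4

The source may hold more compounds than are shown below. What is called first, only, known or untested is meant among the compounds shown, and "the series" means these compounds.

Compound 1 `CC1=CC[C@H](C(C)(C)NC(=S)N/N=C/c2ccccc2)CC1` gives 53900 nM in a functional assay on NCI-H460 cells (Homo sapiens) for inhibition, read by sulforhodamine B assay, with a stated time of 48 h; a lower number here means a stronger inhibitor of growth, a higher number a weaker inhibitor of growth.
Compound 2 `COc1ccc(/C=N/NC(=S)NC(C)(C)[C@H]2CC=C(C)CC2)cc1` gives 47800 nM in this assay.
Compound 3 `CC1=CC[C@H](C(C)(C)NC(=S)N/N=C/c2ccco2)CC1` gives 10800 nM in this assay.

Compound 3 shows the lowest number of the three in this assay. The steps reaching it were a 5.0-fold lower number from compound 1 to compound 3 (0.70 log units; beyond the scatter) and a 4.4-fold lower number from compound 2 to compound 3 (0.65 log units; beyond the scatter), whereas a 1.1-fold lower number from compound 1 to compound 2 (0.05 log units; within the scatter). Compound 4 `CC1=CC[C@H](C(C)(C)NC(=S)N/N=C/c2ccc[nH]2)CC1` differs from compound 3 by 1H-pyrrol-2-yl in place of furan-2-yl on a carbon with a double bond to nitrogen. Within the data shown here, no measured step exchanges one five-membered aromatic ring for another; the measured steps only trade a six-membered aromatic ring for furan-2-yl, so nothing here separates furan-2-yl from 1H-pyrrol-2-yl. In the absence of such evidence, compound 4 is expected to stay near compound 3 in this assay. Compound 4 is estimated at 12000 nM, with a range from 4000 nM to 36000 nM. The expected step is then a 1.1-fold higher number from compound 3 to compound 4 (0.05 log units; within the scatter), not beyond the scatter.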

Compound 4, concentration for total growth inhibition: 57500 nM
The estimate for compound 4 lay 4.8-fold (0.68 log units) below the measured number, outside the stated range (above it).
By their numbers in this assay, from the lowest: compound 3; then compounds 2, 1 and 4 (each within the scatter of the next).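

In this assay, furan-2-yl and 1H-pyrrol-2-yl are not interchangeable on this carbon: the swap gives a 5.3-fold higher number from compound 3 to compound 4 (0.73 log units; beyond the scatter) and so removes the advantage of compound 3. Both a 1.1-fold higher number from compound 1 to compound 4 (0.03 log units; within the scatter) and a 1.2-fold higher number from compound 2 to compound 4 (0.08 log units; within the scatter) lie within the scatter, so among these groups the lower number belongs to furan-2-yl alone, not to five-membered aromatic rings in general. Nothing shown here accounts for the difference between the two rings. Still open, on these data alone, is whether thiophen-2-yl, with sulfur in the ring, would behave like furan-2-yl or like 1H-pyrrol-2-yl.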